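Replacing the carbamoylphenyl with nitrophenyl at the ether end

A few compounds are considered here, and "the series" means these few. Any claim that something is new, unique, unknown or untested is made for them only; others in the source may bear on it.

Three compounds share one core, and differ only in the aryl group sitting on the oxygen of the terminal ether. Compound 1 `CC(C)[C@H](NC(=O)COc1cccc2ccccc12)C(=O)N[C@@H](CC(=O)O)C(=O)COc1ccccc1` carries a plain phenyl; in a functional assay on Jurkat cells (Homo sapiens) (on this read-out lower numbers stand for stronger inhibition and higher numbers for weaker inhibition), compound 1 gives 14000 nM. Compound 2 `CC(C)[C@H](NC(=O)COc1cccc2ccccc12)C(=O)N[C@@H](CC(=O)O)C(=O)COc1cccc(C(F)(F)F)c1` carries 3-(trifluoromethyl)phenyl. In this assay compound 2 gives only a limit, > 100000 nM. Compound 3 `CC(C)[C@H](NC(=O)COc1cccc2ccccc12)C(=O)N[C@@H](CC(=O)O)C(=O)COc1ccc(C(N)=O)cc1` carries 4-carbamoylphenyl. In this assay compound 3 likewise gives only a limit, > 100000 nM, so it stands, with compound 2, at the weak end of the three, and the step between compound 2 and compound 3 is a step that the two limits leave unreadable from compound 2 to compound 3. Both substituted phenyls moved away from compound 1: an at least 7.1-fold higher number from compound 1 to compound 2 (0.85 log units; beyond the scatter) and an at least 7.1-fold higher number from compound 1 to compound 3 (0.85 log units; beyond the scatter), each ending at the limit of > 100000 nM in this assay, at which 2 of the 3 values shown sit.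

Compound 4 `CC(C)[C@H](NC(=O)COc1cccc2ccccc12)C(=O)N[C@@H](CC(=O)O)C(=O)COc1ccccc1[N+](=O)[O-]` is unmeasured. It differs from compound 3 as follows: 2-nitrophenyl in place of 4-carbamoylphenyl on an oxygen on a saturated carbon. Two substituted phenyls already sit at the limit, so a further substituted phenyl is expected to stay weak, with an at least 1.2-fold lower number from compound 3 to compound 4 (0.09 log units; that floor lies within the scatter) expected. Compound 4 is therefore estimated at 80000 nM, between 15000 nM and 300000 nM.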

Compound 4, half-maximal inhibitory concentration: > 100000 nM
Compound 4: only a limit was reported (the forecaster's own chance of this, stated with the estimate: 50%); middle value at least 1.2-fold (0.09 log units) away from the limit.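

In this assay, the loss seen with substituents on the phenyl of the ether end now extends to a third group at a third ring position: an at least 7.1-fold higher number from compound 1 to compound 4 (0.85 log units; beyond the scatter). All three substituted phenyls shown, 3-(trifluoromethyl)phenyl, 4-carbamoylphenyl and 2-nitrophenyl, therefore fall short of the plain phenyl of compound 1, and none of them goes against this pattern. The steps among compound 2, compound 3 and compound 4 cannot be read, since both ends of each step are limits, so these three compounds cannot be ranked and share a single mark: the limit of > 100000 nM in this assay, at which 3 of the 4 values shown sit.

Going by these compounds, whether a smaller group, such as methyl, or an amine on the phenyl would hold the activity of compound 1 remains open. Among these compounds, each substituent also appears at only one ring position, so the effects of group and position cannot be separated.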